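Pentafluoroethyl for a sulfur-based group on the ether ring

The source may report more compounds than this note shows. Statements on the series, on what has been measured and on what is new or still open speak of the compounds shown alone.

Three compounds of the series are measured in a functional assay on CWR22R cells (Homo sapiens) for antiproliferative activity, read by propidium iodide staining, with a stated time of 96 h; on this read-out higher numbers stand for weaker inhibition and lower numbers for stronger inhibition. Compound 1 `CC(O)(COc1cccc(S(F)(F)(F)(F)F)c1)C(=O)Nc1ccc(C(F)(F)F)cc1` gives 15800 nM. Compound 3 `CC(O)(COc1cccc(C(F)(F)C(F)(F)F)c1)C(=O)Nc1ccc(C(F)(F)F)cc1` gives 3600 nM. Compound 2 `CC(O)(COc1ccc(S(F)(F)(F)(F)F)cc1)C(=O)Nc1cc(C(F)(F)F)cc(C(F)(F)F)c1` gives 3200 nM. The change from compound 1 to compound 3 is a group of 7 heavy atoms (2 carbon, 5 fluorine; no ring) in place of a group of 6 heavy atoms (5 fluorine, 1 sulfur; no ring), on an aromatic carbon, and it made a 4.4-fold lower number from compound 1 to compound 3 (0.64 log units; beyond the scatter). The difference between the cores of compound 1 and compound 2 is not broken down here; compound 2 and compound 3 sit within the scatter of each other, so no order between them is read.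

Compound 4 `CC(O)(COc1ccc(C(F)(F)C(F)(F)F)cc1)C(=O)Nc1cc(C(F)(F)F)cc(C(F)(F)F)c1` is not yet measured. From compound 2 to compound 4 the change is a group of 7 heavy atoms (2 carbon, 5 fluorine; no ring) in place of a group of 6 heavy atoms (5 fluorine, 1 sulfur; no ring), on an aromatic carbon. The two places differ: in compound 1 the group stands meta to a large group, in compound 2 para to a large group, so this is the same kind of change rather than the same change. Within the data shown here, the step is expected to be of similar size, a 3.2-fold lower number from compound 2 to compound 4 (0.51 log units; beyond the scatter), resting on the step from compound 1 to compound 3, a 4.4-fold lower number from compound 1 to compound 3 (0.64 log units; beyond the scatter), taken somewhat more cautiously: only that one pair supports it. Compound 4 is therefore expected to give about 1000 nM, likely between 400 nM and 3000 nM.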

Compound 4, half-maximal inhibitory concentration: 2500 nM
The estimate for compound 4 lay 2.5-fold (0.40 log units) below the measured number; the measured number falls inside the stated range.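

In this assay, replacing the sulfur-based group with 1,1,2,2,2-pentafluoroethyl gives a 1.3-fold lower number from compound 2 to compound 4 (0.11 log units; within the scatter), so on the core of compound 2 the change produces no readable difference. Set beside the earlier pair, the change does not carry across the two cores at a constant size: the same change on two cores in this assay, a 4.4-fold lower number (0.64 log units; beyond the scatter) from compound 1 to compound 3 and a 1.3-fold lower number (0.11 log units; within the scatter) from compound 2 to compound 4, 3.4-fold (0.54 log units) apart, beyond the scatter of two such steps. Among these compounds, the step therefore cannot be transferred as a fixed increment, but with only two pairs, whose cores differ in more than one place, the data do not show which part of the core governs its size or how the change would read on a third core.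

Still open is which of the differences between the two cores accounts for the gap, a question that a core differing from either of these in one place only could separate. Also open, on these data alone, is how a nitrile or a longer fluorinated chain would read on the same aromatic carbon in this assay.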